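Swapping the Aminophenyl for a Nitrophenyl

The source may hold more compounds than are shown below. What is called first, only, known or untested is meant among the compounds shown, and "the series" means these compounds.

Measured compounds:
compound 1, `O=[N+]([O-])c1ccccc1COc1ccc(OCCOCCNC2CCCCC2)cc1`, 2880 nM
compound 2, `Nc1cccc(COc2ccc(OCCOCCNC3CCCC3)cc2)c1`, 10800 nM

Of the compounds shown here, two have been measured in a functional assay on SK-OV-3 cells (Homo sapiens) for inhibition, read by CCK-8 assay, with a stated time of 70 h; a higher number here means a weaker inhibitor, a lower number a stronger inhibitor. Compound 1 gives 2880 nM. Compound 2 gives 10800 nM, the highest of the two numbers; the gap between compound 2 and compound 1 lies beyond the scatter, so compound 2 is the weaker of the pair on the numbers shown.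

The next compound, compound 3, `O=[N+]([O-])c1ccccc1COc1ccc(OCCOCCNC2CCCC2)cc1`, has not yet been tested in this assay. Compared with compound 2, it carries 2-nitrophenyl in place of 3-aminophenyl on a saturated chain carbon bound to an oxygen on an aromatic ring; the rest of the molecule, including the cyclopentyl amine at the chain end, is unchanged. For the measured compounds named here, no measured pair shows this change directly. Compound 1 carries the same 2-nitrophenyl group with a cyclohexyl amine, and its number is lower than that of compound 2.

On that basis compound 3 is expected to be a stronger inhibitor than compound 2, with an estimated step of a 3.1-fold lower number from compound 2 to compound 3 (0.49 log units; beyond the scatter). The estimated value for compound 3 in this assay is 3500 nM, with a likely range from 1500 nM to 8000 nM.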

Compound 3, half-maximal inhibitory concentration: 5370 nM
For compound 3 the middle estimate is 1.5-fold (0.19 log units) below the measured one; the range from low to high includes it.
By their numbers in this assay, from the lowest: compounds 1, 3 and 2 (each within the scatter of the next, the first and the last beyond it).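

In this assay, the exchange of 3-aminophenyl for 2-nitrophenyl on a saturated chain carbon bound to an oxygen on an aromatic ring can now be read directly as a 2.0-fold lower number from compound 2 to compound 3 (0.30 log units; within the scatter) and so does not separate the pair on these numbers. For the compounds shown here, the amine end can also be read on its own for the first time: cyclopentyl in place of cyclohexyl on an amine nitrogen gives a 1.9-fold higher number from compound 1 to compound 3 (0.27 log units; within the scatter) and likewise leaves its pair unseparated, so neither single change, taken alone, has yet produced a step beyond the scatter. Nothing measured here offers an explanation for these numbers.

The compounds shown tie the nitro group to the 2-nitrophenyl arrangement and the amino group to the 3-aminophenyl arrangement, so the identity of the group and the place it occupies on the ring cannot be told apart. A 3-nitrophenyl, a 2-aminophenyl or an unsubstituted phenyl on that chain carbon would address this, while a cyclobutyl or cycloheptyl on the amine nitrogen would extend the reading at the other end.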